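Replacing the piperidine tail in a peroxide solubility series

The source may hold more compounds than are shown below. What is called first, only, known or untested is meant among the compounds shown, and "the series" means these compounds.

Compound 2 `c1cc([C@H]2CC[C@]3(CC2)OOC2(O3)C3CC4CC(C3)CC2C4)ccc1OCC1CCNCC1` is the starting point. For the measured compounds named here, in a physicochemical assay for solubility, read by nephelometry, measured as kinetic solubility, with a stated time of 30 min (on this read-out higher numbers stand for higher solubility and lower numbers for lower solubility), compound 2 gives 12.5 ug/mL, the lowest of the two numbers known here. Its nearest neighbour is compound 1 `N[C@H]1CC[C@@H](Oc2ccc([C@H]3CC[C@]4(CC3)OOC3(O4)C4CC5CC(C4)CC3C5)cc2)CC1`, which in this assay gives 25 ug/mL; the step of a 2.0-fold lower number from compound 1 to compound 2 (0.30 log units; within the scatter). Compound 3 `CC(C)(CN)Oc1ccc([C@H]2CC[C@]3(CC2)OOC2(O3)C3CC4CC(C3)CC2C4)cc1` reaches only a limit of the assay in this assay, namely > 100 ug/mL. That limit is the limit of > 100 ug/mL in this assay, at which 1 of the 3 values shown sits. The step of an at least 8.0-fold higher number from compound 2 to compound 3 (0.90 log units; beyond the scatter), and likewise an at least 4.0-fold higher number from compound 1 to compound 3 (0.60 log units; beyond the scatter).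

Compound 4 `CS(=O)(=O)N1CCN(CCCOc2ccc([C@H]3CC[C@]4(CC3)OOC3(O4)C4CC5CC(C4)CC3C5)cc2)CC1` has not yet been measured. It differs from compound 2 in one place: 2-(4-(methylsulfonyl)piperazin-1-yl)ethyl in place of piperidin-4-yl on a saturated chain carbon bound to an oxygen on an aromatic ring. Going by the values given here, none of the measured steps exchanges the piperidin-4-yl for a group of this kind. The two steps that touch the same region show that altering the group on the oxygen on the aromatic ring can have either outcome: one step, a 2.0-fold lower number from compound 1 to compound 2 (0.30 log units; within the scatter), stayed within the scatter, while another, an at least 8.0-fold higher number from compound 2 to compound 3 (0.90 log units; beyond the scatter), went beyond it. Among the compounds with values here, with no measured step matching this change, the step of a 1.3-fold lower number from compound 2 to compound 4 (0.10 log units; within the scatter) is expected to stay within the scatter, with the number for compound 4 lying near that of compound 2. Compound 4 is therefore estimated at 10 ug/mL, within a range from 3 ug/mL to 40 ug/mL.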

Compound 4, solubility: < 1.6 ug/mL
Compound 4 gave a limit, no number (the forecaster's own chance of this, stated with the estimate: 10%); middle value at least 6.2-fold (0.79 log units) away from the limit.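

In this assay, the exchange on a saturated chain carbon bound to an oxygen on an aromatic ring gave an at least 7.8-fold lower number from compound 2 to compound 4 (0.89 log units; beyond the scatter), the only step shown that leads down from compound 2 beyond the scatter. Compound 4 gives a limit of the assay rather than a number, at the low end of what is shown: the limit of < 1.6 ug/mL in this assay, at which 1 of the 4 values shown sits. Compound 3 also gives a limit, at the opposite end, so the compounds that differ only in the group on this oxygen reach both ends of the values shown: the limit of > 100 ug/mL in this assay, at which 1 of the 4 values shown sits.

The compounds shown leave open whether the step belongs to the methylsulfonyl group, the piperazine ring or the longer chain, as 2-(4-(methylsulfonyl)piperazin-1-yl)ethyl brings all of these in together. A 2-(piperazin-1-yl)ethyl group with its free ring amine, or an acetyl group on the piperazine in place of methylsulfonyl, would separate these parts, while the full size of the step stays unread as long as compound 4 stands at a limit.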